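The compounds below may be only part of what the source reports. "The series", "measured", "known", "first", "only" and "open" are said of these compounds alone.

Three compounds have numbers in a functional assay on the whole organism with Rattus norvegicus as the target, at a dose of 100 mg/kg; a higher number here means more inhibition at the dose given (going by the name of the read-out), a lower number less inhibition. Compound 2 `O=c1ccc(-c2ccccc2)nn1CCCC/N=C(\S)Nc1cccc(F)c1` gives 30.4%, the largest of the three. Compound 1 `O=c1ccc(-c2ccccc2)nn1CCCC/N=C(\S)Nc1ccc(S(=O)(=O)O)cc1` gives 25.1%; the step of a number 5.3 percentage points higher from compound 1 to compound 2 (within the scatter) lies within the scatter, so the two cannot be told apart. Compound 3 `C/N=C(/NC#N)NCCCCCn1nc(C)ccc1=O` gives 14.9%, which lies beyond the scatter from compound 2.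

Compound 4 `O=c1ccc(-c2ccccc2)nn1CCCC/N=C(\S)Nc1ccc(F)cc1` differs from compound 2 only in this way: 4-fluorophenyl in place of 3-fluorophenyl on an amine nitrogen. Among the measured compounds shown here, no measured step moves a fluorine within the ring, and the one step that exchanges the ring on this amine nitrogen, a number 5.3 percentage points higher from compound 1 to compound 2 (within the scatter), stays within the scatter. The expectation is therefore a step of a number 0.4 percentage points lower from compound 2 to compound 4 (within the scatter), not beyond the scatter. Compound 4 is estimated at 30%, within the range 18% to 42%.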

Compound 4, a percentage reported as inhibition, in the whole organism at one dose (the size of the read-out at that dose, not a potency): 45.6%
The estimate for compound 4 lay 15.6 percentage points below the measured number; the measured number lies above the stated range.
By their numbers in this assay, from the lowest: compound 3; then compounds 1 and 2 (each within the scatter of the next); then compound 4.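

In this assay, the place of the fluorine on the ring matters: with the same atoms joined differently, 4-fluorophenyl in place of 3-fluorophenyl brings a number 15.2 percentage points higher from compound 2 to compound 4 (beyond the scatter). Fluoro in place of sulfo on an aromatic carbon also now gives a clear change, with a number 20.5 percentage points higher from compound 1 to compound 4 (beyond the scatter), whereas the step to the 3-fluorophenyl compound stayed within the scatter. Nothing measured here accounts for this rise. On these data alone, whether 4-chlorophenyl or 4-methoxyphenyl on this amine nitrogen would match compound 4 remains open, as does how 2-fluorophenyl would compare.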